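Swapping Cyano for Nitro: What the Cell Assay May Show

A few compounds are considered here, and "the series" means these few. Any claim that something is new, unique, unknown or untested is made for them only; others in the source may bear on it.

Measured so far:
Compound 1 `CCOc1cccc(/C=N/NC(=O)c2cnccn2)c1` gives 74% in an ADME assay on J774 cells (Mus musculus) for cytotoxicity, read by MTT assay, with a stated time of 48 h, tested at 50 ug/mL; a lower number here means a stronger effect, a higher number a weaker effect of the compound at the concentration tested.
Compound 2 `N#Cc1cccc(/C=N/NC(=O)c2cnccn2)c1` gives 100% in this assay.

For the measured compounds named here, only one step links these two compounds. Going from the ethoxy-bearing compound 1 to the cyano-bearing compound 2, the number moves a number 26 percentage points higher from compound 1 to compound 2 (beyond the scatter). Compound 2 thus stands highest of the two numbers, and its nearest neighbour, compound 1, lies beyond the scatter below it, so compound 2 shows the weaker effect of the pair in this assay.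

Compound 3 `O=C(N/N=C/c1cccc([N+](=O)[O-])c1)c1cnccn1` differs from compound 2 in a single place: nitro in place of cyano on an aromatic carbon. Going by the values given here, no measured step bears directly on this exchange. Among the compounds with values here, the one step available, from compound 1 to compound 2, concerns cyano in place of ethoxy, not nitro, so it offers no guide to the direction here. With compound 2 already at the top of the numbers seen, the step of a number 8 percentage points lower from compound 2 to compound 3 (within the scatter) is expected to be small, at most modest and downward. Compound 3 is therefore estimated to give about 92%, expected within 72% to 105%.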

Compound 3, a percentage reported as activity, at one concentration (the size of the read-out at that concentration, not a potency): 100%
For compound 3 the middle estimate is 8 percentage points below the measured one; measured number inside the range.
By their numbers in this assay, from the lowest: compound 1; then compounds 2 and 3 (each within the scatter of the next).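

At this place on the ring, an aromatic carbon meta to a large group, nitro and cyano cannot be told apart in this assay, as the step reads no change at the digits printed from compound 2 to compound 3 (within the scatter) and stays within the scatter. The difference seen earlier therefore does not belong to cyano alone, since a second group in place of ethoxy gives a similar result, with a number 26 percentage points higher from compound 1 to compound 3 (beyond the scatter) and beyond the scatter. Among the three compounds, ethoxy is thus the only group whose number stands apart, and the exchange of a nitrile for a nitro group, with its extra heavy atom and extra hydrogen-bond acceptor, leaves no mark that this read-out can separate from the scatter.

As far as these compounds go, three groups at one place make a small sample, so it remains open whether an amine, a carboxylic acid, or a longer chain such as propoxy at this place would fall with ethoxy, with cyano and nitro, or elsewhere. Nothing shown here gives any measured explanation for why ethoxy stands apart or why cyano and nitro read alike.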